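Trimming the Long Chain of Compound 2

A few compounds are considered here, and "the series" means these few. Any claim that something is new, unique, unknown or untested is made for them only; others in the source may bear on it.

Compound 1 (`Cc1cc(O)c(C(=O)Nc2ccccc2)c(=O)o1`) gives > 200000 nM
Compound 2 (`CCCCCCCCCCCCCCNC(=O)c1c(O)cc(C)oc1=O`) gives > 200000 nM

In an ADME assay on L929 cells (Mus musculus, culture collection number NCTC 929) for cytotoxicity, read by MTT assay, with a stated time of 72 h (a higher number here means a weaker inhibitor, a lower number a stronger inhibitor), compound 2 gives > 200000 nM as a limit of the assay, not a number. Both measured compounds sit at that limit (the limit of > 200000 nM in this assay, at which 2 of the 2 values shown sit). Compound 3 (`CCCCCCNC(=O)c1c(O)cc(C)oc1=O`) differs from compound 2 (hydrogen in place of octyl on a saturated chain carbon, six bonds along the chain from an amide-type nitrogen): hydrogen in place of octyl on a saturated chain carbon, six bonds along the chain from an amide-type nitrogen. Within the data shown here, no measured step covers such a change, so in this assay nothing beyond the scatter is expected (a number no higher from compound 2 to compound 3 (the limit leaves the size open)). Compound 3 is estimated at 200000 nM with an expected range of 100000 nM to 400000 nM and may well return only a limit.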

Compound 3, half-maximal inhibitory concentration: 196000 nM
Estimate against measurement, compound 3: 1.0-fold (0.01 log units) above; the range from low to high includes it.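

In this assay compound 3 gives 196000 nM, a measured number. Compound 1 and compound 2 gave only limits. Hydrogen in place of octyl on the saturated chain carbon gives an at least 1.0-fold lower number from compound 2 to compound 3 (0.00 log units; that floor lies within the scatter), and hexyl in place of phenyl on the amide-type nitrogen gives an at least 1.0-fold lower number from compound 1 to compound 3 (0.00 log units; that floor lies within the scatter). Neither change is shown to do more than the scatter, and the true size of each stays open, as most of the values rest on a limit: the limit of > 200000 nM in this assay, at which 2 of the 3 values shown sit.

The compounds shown leave open whether a shorter chain, an amine or a carboxylic acid in place of hexyl on the amide-type nitrogen would give a lower number in this assay.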